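The source may hold more compounds than are shown below. What is called first, only, known or untested is meant among the compounds shown, and "the series" means these compounds.

Measured compounds:
compound 1 `O=C(O)/C(S)=C/c1c[nH]c2cc(F)ccc12` gives 10 nM
compound 2 `O=C(O)/C(S)=C/c1c[nH]c2cc(I)ccc12` gives 170 nM
compound 3 `O=C(O)/C(S)=C/c1ccccc1I` gives 29600 nM

All three were tested in an assay on isolated protein for inhibition of Calpain-1 catalytic subunit (Sus scrofa), read by FRET; on this read-out higher numbers stand for weaker inhibition and lower numbers for stronger inhibition. Compound 1 and compound 2 share one core and differ in a single spot: fluoro in place of iodo on an aromatic carbon. That exchange produced a 17-fold lower number from compound 2 to compound 1 (1.23 log units; beyond the scatter). Compound 3 is built on a different core; how its core differs from that of compound 2 is not broken down here, but its value in this assay stands far above both, with compound 2 the nearer of the two.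

Compound 4 `O=C(O)/C(S)=C/c1ccccc1F` has not yet been measured. It differs from compound 3 by fluoro in place of iodo on an aromatic carbon. This is the same kind of change as from compound 2 to compound 1, not the same change: there the place was part of a fused or bridged system of two rings, meta to a fused ring and para to a fused ring, whereas here the place is a six-membered aromatic ring of carbon only, ortho to a group of 6 heavy atoms. Because a 17-fold lower number from compound 2 to compound 1 (1.23 log units; beyond the scatter) was large, a drop of a 9.9-fold lower number from compound 3 to compound 4 (0.99 log units; beyond the scatter) is expected here too, though with less confidence given the different surroundings. Compound 4 is therefore estimated at 3000 nM, between 700 nM and 15000 nM.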

Compound 4, half-maximal inhibitory concentration: 21900 nM
The estimate for compound 4 lay 7.3-fold (0.86 log units) below the measured number; measured number outside the range, above it.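

In this assay, putting fluoro in place of iodo on the aromatic carbon of this core gave a 1.4-fold lower number from compound 3 to compound 4 (0.13 log units; within the scatter), so here the exchange cannot be told apart from no change at all. Going by these compounds alone, this shows that the size of the step depends on the core that carries it, but with only two pairs it does not show which difference between the cores matters, or how the same exchange would behave on a third core. The large effect seen on the first core therefore did not carry over, and the two steps differ clearly: the same change on two cores in this assay, a 17-fold lower number (1.23 log units; beyond the scatter) from compound 2 to compound 1 and a 1.4-fold lower number (0.13 log units; within the scatter) from compound 3 to compound 4, 13-fold (1.10 log units) apart, beyond the scatter of two such steps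

As far as these compounds go, only fluoro and iodo appear at these places, so it stays open whether chloro, bromo, methyl or methoxy would give a large step on the first core and a small one on the second. Also open, from the compounds shown here alone, is whether either core would keep its value if the carboxylic acid gave way to a methyl ester or an amide.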